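A few compounds are considered here, and "the series" means these few. Any claim that something is new, unique, unknown or untested is made for them only; others in the source may bear on it.

Of the compounds shown here, two sharing one core have been measured in a functional assay (aorta) with Oryctolagus cuniculus as the target; a lower number here means tighter binding, a higher number weaker binding. Compound 1 `COc1cc(C(C)=O)ccc1OCCCN1CCC(C(c2ccc(F)cc2)c2ccc(F)cc2)CC1` gives 1.59 nM, the lower of the two numbers, and so binds tighter than compound 2 `COc1cc(C(C)=O)ccc1OCCCN1CCC(C(c2ccc(C)cc2)c2ccc(C)cc2)CC1`, which gives 15.9 nM. That gap lies beyond the usual scatter of repeated measurements. Compound 3 `COc1cc(C(C)=O)ccc1OCCCN1CCC(C(c2ccc(F)cc2)c2ccccn2)CC1` has not yet been measured. It keeps the shared core but carries pyridin-2-yl in place of one 4-fluorophenyl, on a saturated chain carbon bound to an aromatic carbon and a saturated ring carbon (pyridin-2-yl in place of 4-fluorophenyl on a saturated chain carbon bound to an aromatic carbon and a saturated ring carbon). Among the compounds with values here, no measured pair shows this swap directly, so any expectation is loose. Starting from the low number of compound 1 at 1.59 nM, a moderate rise beyond the scatter, toward weaker binding, is expected. The estimated change is a 5.0-fold higher number from compound 1 to compound 3 (0.70 log units; beyond the scatter). For compound 3 the expected value is 8 nM, with an estimated range of 2 nM to 40 nM.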

Compound 3, dissociation constant: 158 nM
Estimate against measurement, compound 3: 20-fold (1.30 log units) below; the whole stated range lies below it.
By their numbers in this assay, from the lowest: compound 1; then compound 2; then compound 3.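

In this assay, exchanging a single group on the saturated chain carbon bound to an aromatic carbon and a saturated ring carbon produces a 99-fold higher number from compound 1 to compound 3 (2.00 log units; beyond the scatter), a large loss of binding. This place is therefore very sensitive to change: replacing one six-membered aromatic ring with another is far from neutral here, even though pyridin-2-yl differs from 4-fluorophenyl only by losing the fluorine and gaining a ring nitrogen, which counts as a hydrogen-bond acceptor. No supporting measurement explains why binding falls so sharply.

The compounds shown leave open whether the loss follows from removing the fluorine or from adding the nitrogen, a question that plain phenyl at this place could help settle. They also leave open whether pyridin-3-yl or pyridin-4-yl, with the ring nitrogen elsewhere, would behave like pyridin-2-yl.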